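The compounds below may be only part of what the source reports. "The series", "measured", "known", "first", "only" and "open" are said of these compounds alone.

Values in a functional assay on QG-56 cells (Homo sapiens) for antiproliferative activity (a lower number here means a stronger inhibitor, a higher number a weaker inhibitor), so far:
compound 1 `COc1ccc(C(O)(c2cc3cc([N+](=O)[O-])cc(-c4ccccc4)c3o2)c2cncn2C)cc1` gives 4970 nM
compound 2 `Cn1cncc1C(O)(c1ccc(C(=O)OC(C)(C)C)cc1)c1cc2cc([N+](=O)[O-])cc(-c3ccccc3)c2o1` gives 6250 nM
compound 3 `Cn1cncc1C(O)(c1ccc(I)cc1)c1cc2cc([N+](=O)[O-])cc(-c3ccccc3)c2o1` gives > 10000 nM (a limit of the assay, not a number)

Compound 3 stands at the limit of > 10000 nM in this assay, at which 1 of the 3 values shown sits, so it offers a limit and no number to work from.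

Compound 4 `Cn1cncc1C(O)(c1ccc(Br)cc1)c1cc2cc([N+](=O)[O-])cc(-c3ccccc3)c2o1` carries bromo in place of iodo on an aromatic carbon, para to a large group, which reads as 4-iodophenyl to 4-bromophenyl (bromo in place of iodo on an aromatic carbon).

Going by the values given here, no measured step involves bromo. The nearest evidence comes from swaps of the group at this place: a 1.3-fold higher number from compound 1 to compound 2 (0.10 log units; within the scatter), an at least 2.0-fold higher number from compound 1 to compound 3 (0.30 log units; that floor lies within the scatter) and an at least 1.6-fold higher number from compound 2 to compound 3 (0.20 log units; that floor lies within the scatter). The first lies within the scatter, and the floors of the other two also lie within it.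

Since a 1.3-fold higher number from compound 1 to compound 2 (0.10 log units; within the scatter) stayed within the scatter and the two floors are small, no change beyond the scatter is expected in this assay, and no direction is favoured. The expected step is an at least 1.2-fold lower number from compound 3 to compound 4 (0.09 log units; that floor lies within the scatter). A limit rather than a number is also expected to be a real possibility. For compound 4 the estimate is 8000 nM, with an expected range of 4000 nM to 14000 nM.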

Compound 4, half-maximal inhibitory concentration: 1480 nM
Beside the measured number, compound 4's estimate is 5.4-fold (0.73 log units) above it, outside the stated range (below it).
By their numbers in this assay, from the lowest: compound 4; then compounds 1 and 2 (each within the scatter of the next). At a limit, above all of these: compound 3.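

Until now, no step at this aromatic carbon had been shown to exceed the scatter in this assay, but bromo now separates from both methoxy and tert-butoxycarbonyl, with a 3.4-fold lower number from compound 1 to compound 4 (0.53 log units; beyond the scatter) and a 4.2-fold lower number from compound 2 to compound 4 (0.63 log units; beyond the scatter). Iodo and bromo also part clearly despite being a single-atom swap at the same place, with an at least 6.7-fold lower number from compound 3 to compound 4 (0.82 log units; beyond the scatter), so the two halogens cannot be treated as interchangeable here. That last step gives only a minimum size, since compound 3 offers a limit and not a number: the limit of > 10000 nM in this assay, at which 1 of the 4 values shown sits.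

Whether the lower number is particular to bromo or extends to other small groups remains open, as chloro, fluoro and methyl at this place are not among the compounds shown. As far as these compounds go, how an amine or a carboxylic acid there would read in this assay is also open.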